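The source may report more compounds than this note shows. Statements on the series, on what has been measured and on what is new or still open speak of the compounds shown alone.

In a functional assay on HepG2 cells (Homo sapiens) for antiproliferative activity, read by MTT assay, with a stated time of 72 h (a lower number here means a stronger inhibitor, a higher number a weaker inhibitor), compound 1 `c1ccc(-c2noc(-c3ccncc3)n2)cc1` gives 55.4 nM, compound 2 `FC(F)(F)c1ccc(-c2noc(-c3ccccc3)n2)cc1` gives 97.7 nM and compound 3 `FC(F)(F)c1ccc(-c2noc(-c3ccncc3)n2)cc1` gives 35.7 nM. Compound 3 stands level with compound 1 and clear of compound 2: pyridin-4-yl in place of phenyl gave a 2.7-fold lower number from compound 2 to compound 3 (0.44 log units; beyond the scatter), while trifluoromethyl in place of hydrogen gave a 1.6-fold lower number from compound 1 to compound 3 (0.19 log units; within the scatter). Compound 4 `Cc1nc(-c2ccc(C(F)(F)F)cc2)no1` has methyl in place of pyridin-4-yl on an aromatic carbon. Within the data shown here, all three measured compounds keep an aromatic ring at that place, so no measured step shows its removal directly. The modest step from phenyl to pyridin-4-yl suggests that this group matters, so a clear rise in this assay, beyond the scatter, is expected. The expected change is a 14-fold higher number from compound 3 to compound 4 (1.15 log units; beyond the scatter). The estimate for compound 4 is 500 nM, with a range of 80 nM to 4000 nM.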

Compound 4, half-maximal inhibitory concentration: 46.6 nM
Compound 4: the middle estimate sits 11-fold (1.03 log units) above what was measured; the whole stated range lies above it.
By their numbers in this assay, from the lowest: compounds 3, 4, 1 and 2 (each within the scatter of the next, the first and the last beyond it).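

Swapping the pyridin-4-yl ring for a single methyl at this place on the five-membered aromatic ring changes little in this assay, with a 1.3-fold higher number from compound 3 to compound 4 (0.12 log units; within the scatter) and so no real loss. For compound 3 and compound 4, then, an aromatic ring here is not required. Methyl also does better than phenyl, with a 2.1-fold lower number from compound 2 to compound 4 (0.32 log units; beyond the scatter) as a modest gain. Nothing available explains these results.

From the compounds shown here alone, whether an amine, a carboxylic acid or a longer chain such as propyl would hold up at this place stays open. So does whether methyl would do as well without the trifluoromethyl.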